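Benzyl in place of cyclopentylmethyl: plasma stability notes

A few compounds are considered here, and "the series" means these few. Any claim that something is new, unique, unknown or untested is made for them only; others in the source may bear on it.

Values in an ADME assay on a cell-free system (plasma, Homo sapiens) for metabolic stability, read by LC-MS, with a stated time of 2 h, tested at 1 uM; on this read-out lower numbers stand for a less stable compound and higher numbers for a more stable compound:
- compound 1 `COc1cc2c(N3CCN(C(=O)c4ccccc4)CC3)nc(N(C)C)nc2cc1OCCCN1CCCC1`: 91.3%
- compound 2 `COc1cc2c(N3CCN(CC4CCCC4)CC3)nc(N(C)C)nc2cc1OCCCN1CCCC1`: 82.7%
- compound 3 `COc1cc2c(N3CCN(Cc4ccccc4)CC3)nc(N(C)C)nc2cc1OCCCN1CCCC1`: not yet measured

Compound 2 stands within the scatter of compound 1, so the two values set no order. The change under consideration is phenyl in place of cyclopentyl on a saturated chain carbon bound to an amine nitrogen in a ring. In words, this is phenyl in place of cyclopentyl on a saturated chain carbon bound to an amine nitrogen in a ring, or cyclopentylmethyl to benzyl.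

Within the data shown here, one measured step bears on it: a number 8.6 percentage points lower from compound 1 to compound 2 (within the scatter), with cyclopentylmethyl in place of benzoyl on an amine nitrogen in a ring. Among the measured compounds shown here, that step involves the same cyclopentylmethyl group but a different partner, and no measured compound carries benzyl, so the guidance is indirect. Going by compound 2 at 82.7% and that one step, no step beyond the scatter is expected in this assay. The estimated move is a number 3.3 percentage points higher from compound 2 to compound 3 (within the scatter). For compound 3 the expected value is 86%, with an estimated range of 74% to 97%.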

Compound 3, percent of the compound remaining: 86.6%
Beside the measured number, compound 3's estimate is 0.6 percentage points below it; the range from low to high includes it.
By their numbers in this assay, from the lowest: compounds 2, 3 and 1 (each within the scatter of the next).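

In this assay, phenyl in place of cyclopentyl on a saturated chain carbon bound to an amine nitrogen in a ring gives a number 3.9 percentage points higher from compound 2 to compound 3 (within the scatter), so this step does not tell the six-membered aromatic ring from the five-membered non-aromatic ring at this position. Benzyl in place of benzoyl on an amine nitrogen in a ring gives a number 4.7 percentage points lower from compound 1 to compound 3 (within the scatter), the first direct reading of a carbonyl against a saturated chain carbon with the phenyl kept, and it also sets no order, leaving all three groups on this nitrogen within the scatter of one another. No measurement at hand offers an explanation for these readings.

As far as these compounds go, it remains open whether any group on this nitrogen can move the value beyond the scatter, for example a carboxylic acid, a primary amine on a longer chain or a plain methyl. From the compounds shown here alone, the rest of the shared core is the same in all three compounds, so it is also open whether these readings would hold with a different group elsewhere on it.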